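Aryl swap on the five-membered ring nitrogen: compound 4

This account rests on a few compounds, and the source may have more. Where it says the series, first, only, none or still open, it means among the compounds named here.

Going by the values given here, compound 3 `N#CC1=C(N)Oc2c(N)cc3nc4ccccc4nc3c2C12C(=O)N(Cc1cnnn1-c1ccccc1Br)c1ccccc12` is the one member of this set with a number in a functional assay on MCF7 cells (Homo sapiens) for antiproliferative activity, read by MTT assay, with a stated time of 48 h; on this read-out higher numbers stand for weaker inhibition and lower numbers for stronger inhibition: compound 3 gives 30700 nM. Compound 1 `Cc1ccccc1-n1nncc1CN1C(=O)C2(C(C#N)=C(N)Oc3c(N)cc4nc5ccccc5nc4c32)c2ccccc21` returns only a limit in this assay, namely > 50000 nM. Compound 2 `Cc1cccc(-n2nncc2CN2C(=O)C3(C(C#N)=C(N)Oc4c(N)cc5nc6ccccc6nc5c43)c3ccccc32)c1` likewise returns a limit in this assay, > 50000 nM. The step from compound 1 to compound 3 is an at least 1.6-fold lower number from compound 1 to compound 3 (0.21 log units; that floor lies within the scatter), and the step from compound 2 to compound 3 is an at least 1.6-fold lower number from compound 2 to compound 3 (0.21 log units; that floor lies within the scatter); both are read against (the limit of > 50000 nM in this assay, at which 2 of the 3 values shown sit). Between compound 1 and compound 2 the step is a step that the two limits leave unreadable from compound 1 to compound 2.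

Compound 4 `COc1ccc(-n2nncc2CN2C(=O)C3(C(C#N)=C(N)Oc4c(N)cc5nc6ccccc6nc5c43)c3ccccc32)cc1` differs from compound 3 by 4-methoxyphenyl in place of 2-bromophenyl on an aromatic nitrogen. Among the compounds with values here, no measured step covers a methoxyphenyl on this nitrogen. The two methylphenyl analogues sit at the limit, and only the 2-bromophenyl of compound 3 gave a number, so compound 4 is expected to give a weak or limiting result in this assay. The step expected for compound 4 is a 1.6-fold higher number from compound 3 to compound 4 (0.21 log units; within the scatter). The value estimated for compound 4 is 50000 nM, with a range from 20000 nM to 150000 nM.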

Compound 4, half-maximal inhibitory concentration: > 50000 nM
Compound 4: no number, only a limit; the forecaster's own chance of this, stated with the estimate: 55%; the middle value lies on the limit itself.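

In this assay, a methoxy-bearing aryl group on the aromatic nitrogen brings the first hydrogen-bond acceptor to this position, and the result is again a limit rather than a number, with the step being an at least 1.6-fold higher number from compound 3 to compound 4 (0.21 log units; that floor lies within the scatter). The steps to compound 4 from compound 1 and from compound 2 cannot be read, as both ends of each are limits. Compound 3 remains the only member with a number, and the methoxy group adds a third aryl variant to the group at the ceiling: the limit of > 50000 nM in this assay, at which 3 of the 4 values shown sit.

As far as these compounds go, whether the bromo group of compound 3 makes any real difference remains open, as does what a 4-bromophenyl or a 4-aminophenyl would give on this nitrogen. Also open, from the compounds shown here alone, is whether a carboxylic acid on the phenyl ring, or a longer chain in place of the aryl group, would give a number clear of the scatter.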